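From a Bromophenyl to a Chlorophenyl Hydrazone: Tolerance Expected

A few compounds are considered here, and "the series" means these few. Any claim that something is new, unique, unknown or untested is made for them only; others in the source may bear on it.

Compound 1, `O=C(COc1cccc2ccccc12)N/N=C/c1ccccc1Br`, gives in an ADME assay on HEL cells (Homo sapiens) for cytotoxicity (a lower number here means that less compound is tolerated, a higher number that more compound is tolerated), only a limit, >= 20 ug/mL.
Compound 2, `C/C(=N\NC(=O)COc1cccc2ccccc12)c1ccc(O)cc1`, gives in this assay the value 20 ug/mL.
Compound 3, `C/C(=N\NC(=O)COc1cccc2ccccc12)c1ccc(Cl)cc1`, gives in this assay only a limit, >= 4 ug/mL.

Compound 1 therefore stands at a limit in this assay, and its own number is not known; the line the limit of >= 20 ug/mL in this assay, at which 1 of the 3 values shown sits, records that one of the three values sits there. Going by the values given here, the only step between measured neighbours, a step that the limit leaves unreadable from compound 2 to compound 3, is itself unreadable, since compound 3 also sits at a limit, as the line the limit of >= 4 ug/mL in this assay, at which 1 of the 3 values shown sits, records.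

Compound 4, `O=C(COc1cccc2ccccc12)N/N=C/c1cccc(Cl)c1`, differs from compound 1 in one place: 3-chlorophenyl in place of 2-bromophenyl on a carbon with a double bond to nitrogen. Among the compounds with values here, no measured step covers such an exchange of one halophenyl for another, and the one step that exists concerns a different change and gives no size. There is thus no ground to expect a step beyond the usual scatter in this assay in either direction.

Compound 4 is therefore expected to give about 20 ug/mL in this assay, within 8 ug/mL to 50 ug/mL. This estimate means an expected step of a number no higher from compound 1 to compound 4 (the limit leaves the size open), and a limit rather than a number is again thought likely.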

Compound 4, minimum cytotoxic concentration: 100 ug/mL
Compound 4: middle estimate off by 5.0-fold (0.70 log units), on the low side; the measured number lies above the stated range.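

Going by these compounds alone, compound 1 stands only at a limit in this assay, and the step between compound 1 and compound 4 cannot be read, so no new step comes from this result. The compounds shown leave open how large the exchange of 2-bromophenyl for 3-chlorophenyl is.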